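The compounds below may be only part of what the source reports. "The series", "measured", "known", "first", "only" and "open" are said of these compounds alone.

Measured compounds:
compound 1 `COc1ccccc1/C=C/C(=O)NCc1ccc(OCc2nc(C)c(C)nc2C)c(OC)c1`: 7150 nM
compound 2 `COc1ccc(/C=C/C(=O)NCc2ccc(O)c(OC)c2)cc1`: 11400 nM
compound 3 `COc1ccc(/C=C/C(=O)NCc2ccc(OCc3nc(C)c(C)nc3C)c(OC)c2)cc1`: 5050 nM

In a functional assay on SH-SY5Y cells (Homo sapiens) for cytotoxicity, read by MTT assay, with stated times of 24 h and 4 h (a higher number here means that more compound is needed for the effect, a lower number that less compound is needed), compound 3 gives the lowest number of the three; compound 1 lies within the scatter of it, compound 2 beyond it. Compound 4 `COc1cc(CNC(=O)/C=C/c2ccc(OC)c(OC)c2OC)ccc1OCc1nc(C)c(C)nc1C` differs from compound 3 in one place: 2,3,4-trimethoxyphenyl in place of 4-methoxyphenyl on a double-bonded chain carbon bound to a double-bonded chain carbon. Going by the values given here, the only measured step at this ring is a 1.4-fold lower number from compound 1 to compound 3 (0.15 log units; within the scatter), which stays within the scatter; the step of a 2.3-fold lower number from compound 2 to compound 3 (0.35 log units; beyond the scatter) concerns another site and does not bear on the change. On this basis a small step is expected, a 1.1-fold lower number from compound 3 to compound 4 (0.05 log units; within the scatter), with no firm direction. Compound 4 is therefore estimated at 4500 nM, with a range from 1500 nM to 13000 nM.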

Compound 4, half-maximal effective concentration: 3840 nM
Estimate against measurement, compound 4: 1.2-fold (0.07 log units) above; the measured number falls inside the stated range.
By their numbers in this assay, from the lowest: compounds 4, 3, 1 and 2 (each within the scatter of the next, the first and the last beyond it).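

In this assay, the place on a double-bonded chain carbon bound to a double-bonded chain carbon also accepts 2,3,4-trimethoxyphenyl, with a 1.3-fold lower number from compound 3 to compound 4 (0.12 log units; within the scatter) and a 1.9-fold lower number from compound 1 to compound 4 (0.27 log units; within the scatter) both within the scatter. This group is the largest of the three shown here, yet no step at this ring leaves the scatter, so the series does not separate these three rings. No measurement offers an explanation for these small steps.

Going by these compounds, whether an amine or a carboxylic acid on this ring would move the number beyond the scatter remains open. Also open, on these data alone, is whether the 2,3,4-trimethoxyphenyl result holds with hydrogen in place of (3,5,6-trimethylpyrazin-2-yl)methyl on the oxygen.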